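Chain length and growth inhibition of breast cancer cells

The compounds below may be only part of what the source reports. "The series", "measured", "known", "first", "only" and "open" are said of these compounds alone.

Measured so far:
compound 1, `CCCCCCCCCNC[C@@H]1OC[C@H](N)[C@H]1O`, 60300 nM
compound 2, `CCCCCCCCCCCNC[C@@H]1OC[C@H](N)[C@H]1O`, 13100 nM
compound 3, `CCCCCCCCNC[C@@H]1OC[C@H](N)[C@H]1O`, > 128000 nM

All three compounds share one core and differ only in the length of a saturated chain attached to an amine nitrogen. In a functional assay on MCF7 cells (Homo sapiens) for antiproliferative activity, read by MTT assay, with a stated time of 72 h (a lower number here means a stronger inhibitor, a higher number a weaker inhibitor), compound 1 gives 60300 nM. Compound 2 gives 13100 nM in this assay. For compound 3 the assay reports only a limit, > 128000 nM; this is the limit of > 128000 nM in this assay, at which 1 of the 3 values shown sits, and it is a limit rather than a number.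

The change from compound 1 to compound 2 is ethyl in place of hydrogen on a saturated chain carbon, nine bonds along the chain from an amine nitrogen. It brought a 4.6-fold lower number from compound 1 to compound 2 (0.66 log units; beyond the scatter). Compound 3 and compound 1 differ in their cores by hydrogen in place of methyl on a saturated chain carbon, eight bonds along the chain from an amine nitrogen.

Compound 4, `CCCCCCCCCCNC[C@@H]1OC[C@H](N)[C@H]1O`, has not yet been measured. It differs from compound 3 by ethyl in place of hydrogen on a saturated chain carbon, eight bonds along the chain from an amine nitrogen. The place is not the same word for word as in the earlier change: here the carbon is eight bonds along the chain from an amine nitrogen, there nine bonds, so this is the same kind of change, not the same change.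

The expectation for compound 4 rests on the measured step of a 4.6-fold lower number from compound 1 to compound 2 (0.66 log units; beyond the scatter) and on compound 3 sitting at a limit > 128000 nM. A step of an at least 4.2-fold lower number from compound 3 to compound 4 (0.63 log units; beyond the scatter) is expected, of the same direction as the earlier one. Compound 4 is estimated at 30000 nM, expected to lie between 12000 nM and 70000 nM.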

Compound 4, half-maximal inhibitory concentration: 42700 nM
For compound 4 the middle estimate is 1.4-fold (0.15 log units) below the measured one, and the stated range covers the measured number.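

Ethyl in place of hydrogen on a saturated chain carbon again lowers the number, with an at least 2.9-fold lower number from compound 3 to compound 4 (0.47 log units; beyond the scatter), so this change runs in the same direction on both cores: the same change on two cores in this assay, a 4.6-fold lower number (0.66 log units; beyond the scatter) from compound 1 to compound 2 and an at least 2.9-fold lower number (0.47 log units; beyond the scatter) from compound 3 to compound 4; the limit leaves it open whether they differ Taking the chain the other way, hydrogen in place of methyl gives a 3.3-fold higher number from compound 2 to compound 4 (0.51 log units; beyond the scatter), and this too agrees in direction with the matching step on the other core: the same change on two cores in this assay, an at least 2.1-fold higher number (0.32 log units; beyond the scatter) from compound 1 to compound 3 and a 3.3-fold higher number (0.51 log units; beyond the scatter) from compound 2 to compound 4; the limit leaves it open whether they differ What this does not show is whether the size of the change carries over from one core to another, since compound 3 has only a limit and not a number: the limit of > 128000 nM in this assay, at which 1 of the 4 values shown sits.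

Methyl in place of hydrogen gives a 1.4-fold lower number from compound 1 to compound 4 (0.15 log units; within the scatter), which lies within the scatter, so the shortest change in the chain shown here leaves open how finely the response follows chain length. As far as these compounds go, whether a longer chain than that of compound 2 would lower the number further, or whether a branched chain or a chain carrying a hydroxyl group would behave in the same way, remains open.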